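Phenyl for Methylsulfanyl: Expected Gain in Liver Stability

The source may hold more compounds than are shown below. What is called first, only, known or untested is meant among the compounds shown, and "the series" means these compounds.

Compound 1, `CCCCCCCCc1ccc(OCC(=O)Cn2nnc(SC)n2)cc1`: < 5%
Compound 2, `CCCCCCCCc1ccc(OCC(=O)Cn2nnc(-c3ccccc3)n2)cc1`: 33%
Compound 3, `CCCCCCCCc1ccc(OCC(=O)Cn2nnnc2SC)cc1`: 21%

All three were tested in an ADME assay on S9 fraction from liver (Rattus norvegicus) for metabolic stability, read by LC-MS, using NADPH, with a stated time of 30 min; on this read-out higher numbers stand for a more stable compound and lower numbers for a less stable compound. For compound 1 the reading sits at a limit of the assay, (the limit of < 5% in this assay, at which 1 of the 3 values shown sits), so it is not a number. Compound 2 and compound 3 each gave a number, and the number for compound 2 is higher than that for compound 3, beyond the usual scatter.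

Two changes from compound 1 are measured. phenyl in place of methylsulfanyl on an aromatic carbon gives a number at least 28 percentage points higher from compound 1 to compound 2 (beyond the scatter). 5-(methylsulfanyl)-1H-tetrazol-1-yl in place of 5-(methylsulfanyl)-2H-tetrazol-2-yl on a saturated chain carbon bound to a carbonyl carbon gives a number at least 16 percentage points higher from compound 1 to compound 3 (beyond the scatter).

Compound 4, `CCCCCCCCc1ccc(OCC(=O)Cn2nnnc2-c2ccccc2)cc1`, has not yet been measured in this assay. phenyl in place of methylsulfanyl on an aromatic carbon This is the same kind of change as from compound 1 to compound 2, not the same: in compound 4 the changed carbon is next to the ring atom that bears a large group, whereas in compound 2 it is two ring bonds from the ring atom that bears a large group.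

Compound 4 is expected to show a step of about a number 29 percentage points higher from compound 3 to compound 4 (beyond the scatter), because the same kind of change gave a number at least 28 percentage points higher from compound 1 to compound 2 (beyond the scatter). Compound 4 is therefore estimated at 50%, likely between 30% and 70%.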

Compound 4, percent of the compound remaining: 36%
Compound 4: the middle estimate sits 14 percentage points above what was measured; the measured number falls inside the stated range.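

In this assay, phenyl in place of methylsulfanyl gives a number 15 percentage points higher from compound 3 to compound 4 (beyond the scatter), so the rise seen on the core of compound 1 also appears on a second core, although two cores cannot show that a third would behave the same way. Whether the size of the step carries over as well as its direction cannot be said: the same change on two cores in this assay, a number at least 28 percentage points higher (beyond the scatter) from compound 1 to compound 2 and a number 15 percentage points higher (beyond the scatter) from compound 3 to compound 4; the limit leaves it open whether they differ The reading for compound 1 is a limit of the assay and not a number: the limit of < 5% in this assay, at which 1 of the 4 values shown sits.

The compounds shown leave open whether another group in the place of methylsulfanyl, such as an amine or a carboxylic acid, would also raise the percent remaining. They also leave open whether the same swap would still give a rise if the octyl chain shared by all four compounds gave way to a shorter chain.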